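This account rests on a few compounds, and the source may have more. Where it says the series, first, only, none or still open, it means among the compounds named here.

Three compounds set the scene. Compound 1 `CC(C)CCNCCN(C(=O)[C@@H]1C[C@H]1c1ccccc1)c1ccc(-c2ccccc2)cc1` gives 5.1 nM in a functional assay for agonist activity at G protein-coupled receptor 88 (Homo sapiens), read by HTRF and cAMP accumulation; on this read-out higher numbers stand for an effect only at larger amounts of compound and lower numbers for an effect already at smaller amounts. Compound 2 `CC[C@H](C)[C@H](N)CN(C(=O)[C@@H]1C[C@H]1c1ccsc1)c1ccc(-c2ccccc2)cc1` gives 450 nM in this assay. Compound 3 `CC(C)C[C@H](N)CN(C(=O)[C@@H]1C[C@H]1c1ccccc1)c1ccc(-c2cccs2)cc1` gives 1500 nM in this assay. Among these three numbers compound 3 stands highest, meaning its effect is seen only at the largest amount; compound 2 is nearest to it and compound 1 furthest, both gaps lying beyond the usual scatter.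

Compound 4 `Cc1cccc(-c2ccc(N(C[C@@H](N)CC(C)C)C(=O)[C@@H]3C[C@H]3c3ccccc3)cc2)c1` has not yet been measured. Its structure differs from that of compound 3 in one place: 3-methylphenyl in place of thiophen-2-yl on an aromatic carbon. The two compounds with a six-membered carbon ring at that position, compound 1 and compound 2, both show lower numbers than compound 3, although each of them also differs from compound 3 elsewhere, so no single step can be read off directly. Within the data shown here, since no measured pair differs only at this position, the size of the step is uncertain; a move towards a lower number seems more likely than none or a rise, but with a wide margin.

The estimate for compound 4 in this assay is 200 nM, between 40 nM and 1000 nM, which would mean an expected step of a 7.5-fold lower number from compound 3 to compound 4 (0.88 log units; beyond the scatter).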

Compound 4, half-maximal effective concentration: 1200 nM
The estimate for compound 4 lay 6.0-fold (0.78 log units) below the measured number; the measured number lies above the stated range.
By their numbers in this assay, from the lowest: compound 1; then compound 2; then compounds 4 and 3 (each within the scatter of the next).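

Placing 3-methylphenyl where thiophen-2-yl stood gives the first direct reading at this position: in this assay the step is a 1.3-fold lower number from compound 3 to compound 4 (0.10 log units; within the scatter), so the two compounds cannot be told apart. Here a five-membered aromatic ring holding sulfur gives way to a six-membered aromatic ring of carbon only, with two more heavy atoms, yet this exchange does not separate the two numbers, so on this core a six-membered carbon ring with this methyl group brings no measurable gain. Nothing measured here explains why the exchange leaves the two compounds indistinguishable.

As far as these compounds go, it remains open whether plain phenyl at this place, on the core of compound 3, would give a number distinct from those of compound 3 and compound 4, which would show what the methyl group itself adds. From the compounds shown here alone, it is also open whether other groups on the same carbon, such as a pyridine ring or a 3-methoxyphenyl group, would stay level with these two or move clearly away from them.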